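Acetyl to methoxycarbonyl on the active amide

The source may report more compounds than this note shows. Statements on the series, on what has been measured and on what is new or still open speak of the compounds shown alone.

Measured in a functional assay on the whole organism for agonist activity, with Mus musculus as the target (a lower number here means that less compound is needed, a higher number that more compound is needed for the effect), so far:
- compound 1 `CCc1nccn1CC#CCN1CCCC1=O` gives > 100 mg/kg as a limit
- compound 2 `CC(=O)N(C)C(C)C#CCn1ccnc1C` gives > 100 mg/kg as a limit
- compound 3 `CC(=O)N(C)CC#CCN1CCCC1` gives 0.3 mg/kg as a number

For the measured compounds named here, compound 3 stands alone in this set as the only compound with a number. Going by the values given here, compound 1 and compound 2 both sit at the limit of > 100 mg/kg in this assay, at which 2 of the 3 values shown sit, and so give no measured step to compound 3. Their entries are limits and not numbers.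

The next compound is compound 4 `COC(=O)N(C)CC#CCN1CCCC1` and it differs from compound 3 in one place: methoxy in place of methyl on a carbonyl carbon with methoxy in place of methyl on a carbonyl carbon, which also reads as acetyl to methoxycarbonyl.

Among the compounds with values here, no measured step bears on this change. With compound 3 at 0.3 mg/kg as the sole anchor, a moderate step towards a higher dose is expected in this assay and it may lie only a little beyond the scatter. A fall to the limit of the assay is not expected for so small a change.

The estimate means an expected step of a 3.3-fold higher number from compound 3 to compound 4 (0.52 log units; beyond the scatter) in this read-out. For compound 4 the expected value is 1 mg/kg with an estimated range of 0.2 mg/kg to 8 mg/kg in this read-out.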

Compound 4, dose for half-maximal effect: 1.4 mg/kg
Beside the measured number, compound 4's estimate is 1.4-fold (0.15 log units) below it; the range from low to high includes it.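

In this assay, for the compounds shown here, acetyl to methoxycarbonyl gives the one step that can be read, a 4.7-fold higher number from compound 3 to compound 4 (0.67 log units; beyond the scatter). Going by these compounds alone, on a carbonyl carbon whose other neighbour is an amide-type nitrogen, methyl is therefore not the only group compatible with a measurable effect, although methoxy in its place comes with a modest step to a higher dose, beyond the usual scatter. Compound 4 still gives a number and not a limit: the limit of > 100 mg/kg in this assay, at which 2 of the 4 values shown sit.

Steps to compound 1 and compound 2 cannot be read, and one exchange at this carbonyl carbon gives no trend. On these data alone, it remains open whether ethoxy, a longer alkoxy chain or an amine such as dimethylamino on the same carbon would stay close to compound 3 or move further towards a higher dose, and whether the step from methyl to methoxy would keep its size on a different core.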